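The compounds below may be only part of what the source reports. "The series", "measured", "known", "first", "only" and "open" are said of these compounds alone.

Compound 2, with the structure `C=CC(C)OC(=O)/C=C(C)/C=C/CC(C)CCCC(C)(C)OC`, sits lowest among the three numbers measured in a physicochemical assay for lipophilicity; a lower number here means a more polar compound, a higher number a more lipophilic compound: compound 2 gives 5.94. Its nearest neighbour is compound 3, `CC(/C=C/CC(C)CCCC(C)C)=C\C(=O)NCC(C)C`, which in this assay gives 6.19, a gap that lies within the scatter; furthest is compound 1, `CC#CCOC(=O)/C=C(C)/C=C/CC(C)CCCC(C)C`, which gives 6.4, a gap that lies beyond the scatter.

Compound 4, `CCC(C)C(=O)/C=C(C)/C=C/CC(C)CCCC(C)(C)OC`, has not yet been measured. Among the measured compounds shown here, it differs from compound 2 in one place: sec-butyl in place of (1-methylprop-2-en-1-yl)oxy on a carbonyl carbon The only measured step that also changes the group on the carbonyl carbon is the one from compound 1 to compound 3, where isobutylamino replaced (but-2-yn-1-yl)oxy and the number moved by a number 0.21 log units lower from compound 1 to compound 3 (within the scatter). That step exchanges an oxygen-linked group for a nitrogen-linked one, not for a carbon-linked one, so it is only a loose guide. On this basis he expects no step beyond the scatter, or at most a small rise: for compound 4 the estimated value in this assay is 6.1, with a range from 5.6 to 6.6. The expected step from compound 2 to compound 4 is therefore a number 0.16 log units higher from compound 2 to compound 4 (within the scatter).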

Compound 4, partition coefficient: 6.02
Estimate against measurement, compound 4: 0.08 log units above, and the stated range covers the measured number.
By their numbers in this assay, from the lowest: compounds 2, 4, 3 and 1 (each within the scatter of the next, the first and the last beyond it).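

In this assay, a carbon-linked group on this carbonyl carbon gives a number 0.08 log units higher from compound 2 to compound 4 (within the scatter), so sec-butyl can take the place of (1-methylprop-2-en-1-yl)oxy without a step beyond the scatter, although the leaving group carries a hydrogen-bond acceptor and a double bond and sec-butyl carries neither. Among the compounds shown here, until now the only step read at this place was the exchange for a nitrogen-linked group, a number 0.21 log units lower from compound 1 to compound 3 (within the scatter), and the two steps together show oxygen-linked, nitrogen-linked and carbon-linked groups here with no step beyond the scatter. Nothing at hand gives a reason for this result.

The compounds shown leave open whether a carboxylic acid or a primary amine-bearing chain on this carbonyl carbon would give a step beyond the scatter. They also leave open what a phenyl group would do there.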